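The compounds below may be only part of what the source reports. "The series", "measured", "known", "first", "only" and "open" are said of these compounds alone.

Working notes on the series. Three analogues share one core and have been looked at in a functional assay on the whole organism (strain Sprague-Dawley) for inhibition, with Rattus norvegicus as the target, with a stated time of 0.5 h, at a dose of 5 mg/kg by the oral route; on this read-out lower numbers stand for less inhibition and higher numbers for more inhibition at the one dose given (going by the name of the read-out). Compound 1, `CCCSc1nc(N[C@@H]2C[C@H]2c2ccc(F)c(F)c2)c2nnn([C@@H]3C[C@H](OCCOC(=O)c4cccnc4)[C@@H](O)[C@H]3O)c2n1`, is recorded in this assay as "not active" (no number reported). Compound 2, `CCCSc1nc(N[C@@H]2C[C@H]2c2ccc(F)c(F)c2)c2nnn([C@@H]3C[C@H](OCCOC(=O)OCC(C)C)[C@@H](O)[C@H]3O)c2n1`, has no result in this assay: "not determined" (no result reported). Among the measured compounds shown here, compound 3, `CCCSc1nc(N[C@@H]2C[C@H]2c2ccc(F)c(F)c2)c2nnn([C@@H]3C[C@H](OCCOC(=O)C(C)(C)C)[C@@H](O)[C@H]3O)c2n1`, is the only member with a number: in this assay compound 3 gives 46.1%. For the measured compounds named here, with one number and two entries without a number, nothing can be said about order within the measured set, and no step between measured compounds is available.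

The unmeasured compound 4 is `CCCSc1nc(N[C@@H]2C[C@H]2c2ccc(F)c(F)c2)c2nnn([C@@H]3C[C@H](O)[C@@H](O)[C@H]3O)c2n1`. It differs from compound 3 by hydrogen in place of 2-(((tert-butyl)carbonyl)oxy)ethyl on an oxygen on a saturated carbon. The change removes the whole side chain named under the difference and leaves a bare hydroxyl at that place on the saturated ring carbon. Going by the values given here, no pair tells how this assay answers such a change, so the expectation rests on the single value of compound 3 alone.

The step in this assay from compound 3 to compound 4 is expected to be upward, beyond the scatter, at about a number 15.9 percentage points higher from compound 3 to compound 4 (beyond the scatter), though with wide uncertainty. Compound 4 is therefore estimated to give roughly 62% in this assay, within a range from 30% to 90%.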

Compound 4, a percentage reported as inhibition, in the whole organism at one dose (the size of the read-out at that dose, not a potency): 45.7%
Beside the measured number, compound 4's estimate is 16.3 percentage points above it, within the range that was stated.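

In this assay, replacing the whole 2-(((tert-butyl)carbonyl)oxy)ethyl group with hydrogen on this oxygen gives a number 0.4 percentage points lower from compound 3 to compound 4 (within the scatter), so the two compounds cannot be told apart on this read-out at the one dose given. Among the compounds shown here, this is the first reading at this place: a bare hydroxyl on the saturated ring carbon and the full side chain both give a number within the scatter of each other, whereas compound 1, which carries a different ester side chain on the same oxygen, is recorded as "not active" (no number reported). Nothing measured here bears on why compound 3 and compound 4 read alike.

Going by these compounds, what stays open is whether other groups on this oxygen, such as a 2-aminoethyl group, a carboxymethyl group or a longer plain alkyl chain, would also fall within the scatter of compound 4 or would behave as compound 1 does. The single dose and single time also leave open whether compound 3 and compound 4 would still read alike under other conditions of this assay.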